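Removing the anilino link in a cytotoxicity series

This account rests on a few compounds, and the source may have more. Where it says the series, first, only, none or still open, it means among the compounds named here.

Compound 1 `C=C[C@@](C)(/C=C/c1ccc(Nc2ccc(F)c(F)c2)cc1)CCC=C(C)C`: > 36600 nM
Compound 2 `C=C[C@@](C)(/C=C/c1ccc(Nc2cc(F)c(F)c(F)c2)cc1)CCC=C(C)C`: > 36600 nM

In an ADME assay on BJ cells (Homo sapiens) for cytotoxicity, with a stated time of 72 h (a lower number here means that less compound is needed, a higher number that more compound is needed for the effect), compound 1 gives > 36600 nM, which is a limit of the assay rather than a number. Compound 2 gives > 36600 nM in this assay, likewise a limit. The step that the two limits leave unreadable from compound 1 to compound 2 is therefore not readable, as both values sit at the limit of > 36600 nM in this assay, at which 2 of the 2 values shown sit. Compound 3 `C=C[C@@](C)(/C=C/c1ccc(-c2ccc(Cl)c(Cl)c2)cc1)CCC=C(C)C` differs from compound 1 by 3,4-dichlorophenyl in place of (3,4-difluorophenyl)amino on an aromatic carbon. Among the compounds with values here, no measured step bears on this change, and compound 1 stands only at a limit. Compound 3 is expected to give 36600 nM in this assay, within 15000 nM to 90000 nM. The step of a number no higher from compound 1 to compound 3 (the limit leaves the size open) is expected to stay within the scatter.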

Compound 3, half-maximal effective concentration: > 36600 nM
Compound 3: a limit, no number (the forecaster's own chance of this, stated with the estimate: 65%); the middle value sits exactly at the limit.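

No new step can be read from compound 1 to compound 3, as both stand only at a limit: the limit of > 36600 nM in this assay, at which 3 of the 3 values shown sit.

The compounds shown leave open whether 3,4-dichlorophenyl in place of (3,4-difluorophenyl)amino changes the read-out in this assay at all.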